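Phenoxy-linked serine phosphate esters: chloro for methyl step

A few compounds are considered here, and "the series" means these few. Any claim that something is new, unique, unknown or untested is made for them only; others in the source may bear on it.

Measured so far:
compound 1, `N[C@@H](COP(=O)(O)OCCCOC(=O)CCc1ccccc1OCCCCOc1ccccc1)C(=O)O`, in an assay on cells for activation of probable G-protein coupled receptor 34 (Mus musculus), with a stated time of 1 h (on this read-out higher numbers stand for larger maximal responses and lower numbers for smaller maximal responses), gives 0.033
compound 2, `N[C@@H](COP(=O)(O)OCCCOC(=O)CCc1ccccc1OCc1cccc(Oc2ccccc2)c1)C(=O)O`, gives 0.48
compound 3, `Cc1ccccc1Oc1cccc(COc2ccccc2CCC(=O)OCCCOP(=O)(O)OC[C@H](N)C(=O)O)c1`, gives 0.28

Compound 3 stands second highest of the three numbers. Its nearest neighbour is compound 2, which lies higher by a step beyond the scatter; compound 1 lies furthest away, lower than compound 3 by a step also beyond the scatter. Among the measured compounds shown here, the one step between measured compounds that differ in a single place is a number 0.20 lower from compound 2 to compound 3 (beyond the scatter), where the methyl enters on an aromatic carbon of the terminal ring.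

The next compound, compound 4, `N[C@@H](COP(=O)(O)OCCCOC(=O)CCc1ccccc1OCc1cccc(Oc2ccccc2Cl)c1)C(=O)O`, differs from compound 3 by chloro in place of methyl on an aromatic carbon. For the measured compounds named here, no measured pair shows chloro set against methyl at this place; the only step touching this aromatic carbon, a number 0.20 lower from compound 2 to compound 3 (beyond the scatter), concerns methyl against hydrogen and is of modest size. The change from compound 3 to compound 4 exchanges one heavy atom for one heavy atom, with no ring, no donor, no acceptor and no charge entering or leaving, so the expected step in this assay is a number 0.020 higher from compound 3 to compound 4 (within the scatter), not beyond the scatter in either direction. Compound 4 is therefore expected to give 0.3, with a range from 0.15 to 0.5.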

Compound 4, intrinsic activity: the largest response reached, as a fraction of the reference agonist's: 0.069
Compound 4: the middle estimate sits 0.23 above what was measured; the measured number lies below the stated range.
By their numbers in this assay, from the lowest: compounds 1 and 4 (each within the scatter of the next); then compound 3; then compound 2.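

In this assay, the change from 2-methylphenyl to 2-chlorophenyl is not a silent exchange of one heavy atom for another, although no ring, donor, acceptor or charge enters or leaves: the step is a number 0.21 lower from compound 3 to compound 4 (beyond the scatter). Against hydrogen on the same aromatic carbon, chloro gives a number 0.41 lower from compound 2 to compound 4 (beyond the scatter), while methyl gives a number 0.20 lower from compound 2 to compound 3 (beyond the scatter), so the three compounds that differ only here fall in the order compound 2, compound 3, compound 4, with each step beyond the scatter. The data at hand offer nothing that accounts for this order.

Going by these compounds, whether fluoro, methoxy or trifluoromethyl on this aromatic carbon would continue the same order remains open, and these three compounds cannot separate the identity of the group from any wider trend. Also open, on these data alone, is whether chloro on another carbon of the same ring would give a step of similar size, or whether this drop in maximal response is particular to the place ortho to a large group.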